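Bromo for nitro on the fused ring of compound 2

The compounds below may be only part of what the source reports. "The series", "measured", "known", "first", "only" and "open" are said of these compounds alone.

Two compounds of the series have a number. Compound 1 `Cc1cc(C)c2c(c1)CN(c1ccc3c(=O)cc(-c4ccccc4)oc3c1)CO2` gives 48.4% in a functional assay on MCF7 cells (Homo sapiens) for inhibition, read by MTT assay, with a stated time of 48 h, tested at 60 ug/mL; a higher number here means more inhibition of growth at the concentration tested, a lower number less inhibition of growth. Compound 2 `O=c1cc(-c2ccccc2)oc2cc(N3COc4c(cccc4[N+](=O)[O-])C3)ccc12` gives 15.7% in this assay and so stands lowest of the two, with compound 1 the nearest neighbour, a gap that is beyond the scatter.

Compound 3 `O=c1cc(-c2ccccc2)oc2cc(N3COc4c(Br)cccc4C3)ccc12` is derived from compound 2 by one change: bromo in place of nitro on an aromatic carbon. Going by the values given here, no measured pair shows this change, so the size of the step is open. Among the compounds with values here, compound 2 carries the lowest number in the set, and the only other compound, compound 1, without a nitro, gives 48.4%, so the expectation for compound 3 is a rise, of modest size, that may not exceed the scatter; the step expected from compound 2 to compound 3 is a number 12.3 percentage points higher from compound 2 to compound 3 (beyond the scatter). Compound 3 is therefore estimated at 28%, within 10% to 48%.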

Compound 3, percent growth inhibition at one concentration: 19.5%
The estimate for compound 3 lay 8.5 percentage points above the measured number, within the range that was stated.
By their numbers in this assay, from the lowest: compounds 2 and 3 (each within the scatter of the next); then compound 1.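

In this assay, going by these compounds alone, bromo in place of nitro on an aromatic carbon, ortho to a fused ring and meta to a fused ring, gives a number 3.8 percentage points higher from compound 2 to compound 3 (within the scatter) and is the first single-place comparison. At this position, the two groups therefore cannot be told apart, even though they differ in heavy atoms and hydrogen-bond acceptors as counted. No measurement on hand bears on the reason for this result.

Compound 1 differs from compound 2 and compound 3 in more than one place, so its higher number cannot be assigned to this position alone. On these data alone, whether a single methyl, an amine or a carboxylic acid on this carbon would read differently from nitro and bromo remains open, as does the contribution of the other methyl of compound 1.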